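The source may report more compounds than this note shows. Statements on the series, on what has been measured and on what is new or still open speak of the compounds shown alone.

Measured so far in a functional assay on MV4-11 cells (Homo sapiens) for inhibition, read by resazurin assay, with a stated time of 72 h; on this read-out higher numbers stand for weaker inhibition of growth and lower numbers for stronger inhibition of growth
- compound 1 `CC(=O)c1ccc(-c2cncc(Cl)c2N2CCC3(CCNC3=O)CC2)s1` at 1440 nM
- compound 2 `Cn1cccc1-c1cncc(Cl)c1N1CCC2(CCNC2=O)CC1` at 900 nM

On these two numbers, compound 2 cannot be separated from compound 1. Going by the values given here, the only measured step is a 1.6-fold lower number from compound 1 to compound 2 (0.20 log units; within the scatter).

The next compound is compound 3 `O=C1NCCC12CCN(c1c(Cl)cncc1-c1cn[nH]c1)CC2`, which has 1H-pyrazol-4-yl in place of 1-methyl-1H-pyrrol-2-yl on an aromatic carbon of a six-membered aromatic ring with 1 nitrogen. The counted difference is 1H-pyrazol-4-yl in place of 1-methyl-1H-pyrrol-2-yl on an aromatic carbon.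

The measured step bears on this change, as it exchanges the group on the same aromatic carbon. Replacing 5-acetylthiophen-2-yl with 1-methyl-1H-pyrrol-2-yl gave only a small change, so the evidence points to a step within the scatter in this assay, with no direction favoured. Among the compounds with values here, this rests on a single pair, and no measured compound carries 1H-pyrazol-4-yl, so the range is kept wide.

The expected change is a 1.1-fold lower number from compound 2 to compound 3 (0.02 log units; within the scatter). For compound 3 the estimated value is 850 nM, with an expected range from 300 nM to 2500 nM.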

Compound 3, concentration for 50% growth inhibition: 8520 nM
Estimate against measurement, compound 3: 10-fold (1.00 log units) below; measured number above the stated range.
By their numbers in this assay, from the lowest: compounds 2 and 1 (each within the scatter of the next); then compound 3.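

In this assay, the aromatic carbon ortho to a large group proves sensitive to the group it carries, a point the earlier exchange could not show, since a 1.6-fold lower number from compound 1 to compound 2 (0.20 log units; within the scatter) stayed within the scatter. Placing 1H-pyrazol-4-yl there gives a 9.5-fold higher number from compound 2 to compound 3 (0.98 log units; beyond the scatter), and the comparison with the 5-acetylthiophen-2-yl group points the same way, with a 5.9-fold higher number from compound 1 to compound 3 (0.77 log units; beyond the scatter), so the two earlier groups both sit on the lower side of compound 3. The data offer no measurement that explains this rise.

Compared with 1-methyl-1H-pyrrol-2-yl, the entering group has two ring hetero atoms in place of one and one hydrogen-bond donor in place of none, and the compounds shown do not tell these two differences apart; a 1-methyl-1H-pyrazol-4-yl group on the same carbon would bear directly on that question. Going by these compounds, the chloro group and the rest of the core are the same in all three compounds, so it also remains open how this position would respond to a non-ring substituent such as an amine, or to a plain phenyl ring.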